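The source may hold more compounds than are shown below. What is called first, only, known or untested is meant among the compounds shown, and "the series" means these compounds.

Compound 1 `C#C[C@H](O)/C=C/CCCCC/C=C\CCCC/C=C\CCCCCCCCC/C=C/[C@@H](O)C#C`: 160 nM
Compound 2 `C#C[C@H](O)/C=C/CCCCCCC/C=C\CCCC/C=C\CCCCCCCCC/C=C/[C@@H](O)C#C`: 160 nM

In a functional assay on A549 cells (Homo sapiens) for cytotoxicity (on this read-out lower numbers stand for stronger inhibition and higher numbers for weaker inhibition), compound 2 gives 160 nM, level with compound 1 at 160 nM. Compound 3 `C#C[C@H](O)/C=C/CCCCCCCCC/C=C\CCCC/C=C\CCCCCCCCC/C=C/[C@@H](O)C#C` has not yet been measured. It differs from compound 2 as follows: a group of 8 heavy atoms (7 carbon, 1 oxygen; no ring) in place of a group of 6 heavy atoms (5 carbon, 1 oxygen; no ring), on a saturated chain carbon, seven bonds along the chain from a double-bonded chain carbon. This is the same kind of swap as the one that links the two measured compounds, a larger group of 8 heavy atoms replacing a group of 6 heavy atoms. There the place was on a saturated chain carbon, five bonds along the chain from a double-bonded chain carbon, whereas here it is seven bonds along.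

Among the measured compounds shown here, only one measured step bears on this change: no change at the digits printed from compound 1 to compound 2 (within the scatter), which lies within the scatter. That single step gives no direction to follow, so no shift beyond the scatter is expected. One step cannot show whether the same holds for a further swap, which is why the range stays fairly wide. The expected change is no change at the digits printed from compound 2 to compound 3 (within the scatter). Compound 3 is estimated at 160 nM, with an expected range from 80 nM to 330 nM.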

Compound 3, half-maximal inhibitory concentration: 160 nM
Compound 3: the middle estimate sits on the measured number at the digits printed; low and high end bracket the measured number.
By their numbers in this assay, from the lowest: compounds 1, 2 and 3 (each within the scatter of the next).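

In this assay the group of 8 heavy atoms in place of the group of 6 heavy atoms, now on a saturated chain carbon seven bonds along the chain from a double-bonded chain carbon, gives no change at the digits printed from compound 2 to compound 3 (within the scatter) and so matches what the same kind of swap did at five bonds along. Taken as a single change, the group of 10 heavy atoms in place of the group of 6 heavy atoms gives no change at the digits printed from compound 1 to compound 3 (within the scatter) as well, so across these three compounds the two swaps do not add up to a shift that one swap alone might have hidden. Nothing measured here explains why the read-out stays level across these chain lengths.

As far as these compounds go, how far this flat stretch extends remains open, since a longer chain than the group of 10 heavy atoms or a shorter one than the group of 6 heavy atoms could behave differently. Also unknown is whether the same tolerance would hold for a different kind of change, such as an amine or a carboxylic acid in place of the hydroxyl group.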